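Furan-2-yl amide in a weakly antiproliferative thiazole series

The source may report more compounds than this note shows. Statements on the series, on what has been measured and on what is new or still open speak of the compounds shown alone.

The series shares one core, and within it the benzamide ring carried on the aniline nitrogen is varied. Compound 1 `CCOC(=O)c1sc(-c2cccc(NC(=O)c3ccccc3)c2)nc1Nc1ccc(N2CCN(C)CC2)cc1` bears the unsubstituted phenyl amide, compound 2 `CCOC(=O)c1sc(-c2cccc(NC(=O)c3cccc(F)c3)c2)nc1Nc1ccc(N2CCN(C)CC2)cc1` the 3-fluorophenyl amide and compound 3 `CCOC(=O)c1sc(-c2cccc(NC(=O)c3ccc(Cl)cc3)c2)nc1Nc1ccc(N2CCN(C)CC2)cc1` the 4-chlorophenyl amide. In a functional assay on Raji cells (Homo sapiens) for antiproliferative activity, read by CCK-8 assay, with a stated time of 72 h (a lower number here means a stronger inhibitor, a higher number a weaker inhibitor), compound 2 gives 21200 nM, a weak result. For compound 1 the outcome in this assay is "not determined" (no result reported), and for compound 3 it is likewise "not determined" (no result reported), so compound 3 has no single number to stand on, and the only numerical anchor in the set is compound 2.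

Compound 4 `CCOC(=O)c1sc(-c2cccc(NC(=O)c3ccco3)c2)nc1Nc1ccc(N2CCN(C)CC2)cc1` is reached from compound 3 by the change (furan-2-yl in place of 4-chlorophenyl on a carbonyl carbon). Within the data shown here, no measured pair shows what such a change does here, so the expectation rests on the weak potency of compound 2 alone. Compound 4 is therefore expected to remain weak in this assay, at an estimated 20000 nM, with a plausible range from 5000 nM to 80000 nM.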

Compound 4, half-maximal inhibitory concentration: 15100 nM
Compound 4: the middle estimate sits 1.3-fold (0.12 log units) above what was measured; measured number inside the range.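

With this result the series has a second number. Compound 4 shows that furan-2-yl, one five-membered aromatic ring with 1 hetero atom, can stand in place of 3-fluorophenyl on a carbonyl carbon with no change beyond the scatter in this assay: the step reads a 1.4-fold lower number from compound 2 to compound 4 (0.15 log units; within the scatter), so both compounds remain weak. Compound 1 and compound 3 have no number, so the steps that would link them to compound 4 cannot be read, including the one from 4-chlorophenyl to furan-2-yl. Nothing available explains why these two amides read alike.

On these data alone, what remains open is whether any group on this carbonyl carbon can lift the series out of this weak range. An aminomethyl group or a carboxylic acid on the benzamide ring, or a longer alkyl chain in place of that ring, is not among the compounds shown.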